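The compounds below may be only part of what the source reports. "The series", "measured", "known", "first", "only" and "open" are said of these compounds alone.

Measured in a functional assay on KB cells (Homo sapiens) for antiproliferative activity, read by sulforhodamine B assay, with a stated time of 3 days; a higher number here means that more compound is needed for the effect, a lower number that less compound is needed
compound 1 `CCC1=C(O)c2c(oc(-c3ccc(C(C)C)cc3)cc2=O)C(CC)(CC)C1=O` gives 8.13 uM
compound 2 `CCC1=C(O)c2c(oc(-c3ccc(O)cc3)cc2=O)C(CC)(CC)C1=O` gives 20.6 uM
compound 3 `CCC1=C(O)c2c(oc(-c3ccc(COC)cc3)cc2=O)C(CC)(CC)C1=O` gives > 52.4 uM which is a limit and not a number

Compound 3 has only a limit, and the limit of > 52.4 uM in this assay, at which 1 of the 3 values shown sits, is all that is known of it. Compound 4 `CCC1=C(O)c2c(oc(-c3cccc(OC)c3)cc2=O)C(CC)(CC)C1=O` carries 3-methoxyphenyl in place of 4-(methoxymethyl)phenyl, and 3-methoxyphenyl in place of 4-(methoxymethyl)phenyl on an aromatic carbon counts that change. Within the data shown here, no measured step makes this exact swap. The nearest evidence is an at least 6.4-fold higher number from compound 1 to compound 3 (0.80 log units; beyond the scatter) and an at least 2.5-fold higher number from compound 2 to compound 3 (0.40 log units; beyond the scatter) where methoxymethyl enters and the number rises. Removing methoxymethyl in compound 4 should therefore lower the number in this assay by a modest step. The expected size is an at least 2.0-fold lower number from compound 3 to compound 4 (0.32 log units; beyond the scatter) by this estimate. For compound 4 the estimate is 25 uM with an expected range from 10 uM to 60 uM in this assay.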

Compound 4, concentration for half-maximal effect: 13.3 uM
Compound 4: middle estimate off by 1.9-fold (0.27 log units), on the high side; the range from low to high includes it.
By their numbers in this assay, from the lowest: compounds 1, 4 and 2 (each within the scatter of the next, the first and the last beyond it). At a limit, above all of these: compound 3.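

Compound 3 gives > 52.4 uM in this assay, which is a limit and not a number. Replacing its 4-(methoxymethyl)phenyl with 3-methoxyphenyl gives an at least 3.9-fold lower number from compound 3 to compound 4 (0.59 log units; beyond the scatter), so this place tolerates an ether-bearing ring after all. The other two comparisons stay small, with a 1.5-fold lower number from compound 2 to compound 4 (0.19 log units; within the scatter) and a 1.6-fold higher number from compound 1 to compound 4 (0.21 log units; within the scatter), both within the scatter.

The group and its place on the ring change together here, and the compounds shown cannot tell which of the two matters. Going by these compounds, how an amine or a carboxylic acid on this ring would read remains open.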